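The compounds below may be only part of what the source reports. "The series", "measured", "known", "first", "only" and "open" are said of these compounds alone.

The series shares one core, and three members have already been measured. Compound 2, `CC(C)C(c1nnc[nH]1)c1ccc(-c2ccc3cccc(F)c3c2)[nH]c1=O`, was tested in an ADME assay on microsomes from liver (Rattus norvegicus) for metabolic stability (on this read-out lower numbers stand for a shorter-lived compound and higher numbers for a longer-lived compound), where compound 2 gives 0.552 h. Compound 1, `CCC(CC)(c1nnc[nH]1)c1ccc(-c2ccc3cc(F)cc(F)c3c2)[nH]c1=O`, gives 1.26 h in this assay. Compound 3, `CCn1ncc2c(F)cc(-c3ccc(C(CC)(CC)c4ncn(C)n4)c(=O)[nH]3)cc21`, is recorded in this assay only as a limit of the assay, > 3 h, and not as a number; this is the limit of > 3 h in this assay, at which 1 of the 3 values shown sits. Among the two numbers that exist, compound 2 therefore stands lowest, and compound 1 sits higher by a gap that goes beyond the usual scatter of the assay. Going by the values given here, no two of the measured compounds differ in a single place, so no measured step is available to lean on.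

Compound 4, `CC(C)C(/C=C1\CCNC1=O)c1ccc(-c2ccc3cccc(F)c3c2)[nH]c1=O`, has not yet been measured. It departs from compound 2 in one place: a group of 7 heavy atoms (5 carbon, 1 nitrogen, 1 oxygen; one five-membered non-aromatic ring with 1 hetero atom) in place of a group of 5 heavy atoms (2 carbon, 3 nitrogen; one five-membered aromatic ring with 3 hetero atoms), on a saturated chain carbon bound to an aromatic carbon and a saturated chain carbon. Among the compounds with values here, the data offer no measured step of this kind, and no evidence about what the entering group does to metabolic stability. The step from compound 2 to compound 4 in this assay is therefore expected to be small, a 1.2-fold lower number from compound 2 to compound 4 (0.09 log units; within the scatter), leaning if anything downward but plausibly within the scatter. On that basis compound 4 is estimated to give 0.45 h in this assay, with a range from 0.2 h to 1.1 h.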

Compound 4, half-life: 0.345 h
For compound 4 the middle estimate is 1.3-fold (0.12 log units) above the measured one; measured number inside the range.
By their numbers in this assay, from the lowest: compounds 4 and 2 (each within the scatter of the next); then compound 1. At a limit, above all of these: compound 3.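

Going by these compounds alone, this is the only measured step that changes a single place, the saturated chain carbon bound to an aromatic carbon and a saturated chain carbon. Replacing the 4H-1,2,4-triazol-3-yl group with a group holding one five-membered non-aromatic ring with 1 hetero atom gives, in this assay, a 1.6-fold lower number from compound 2 to compound 4 (0.20 log units; within the scatter). The aromatic triazole can therefore leave this position without a difference that can be told apart from the scatter of repeated measurements, although nothing shown explains why the half-life holds or bears on a cause for this result.

The compounds shown leave open whether the same exchange would also stay within the scatter on the core of compound 1, which differs from compound 2 in its chain and its fluorine pattern. They also leave open whether a different group at this chain carbon, such as a carboxylic acid, a primary amine or an open-chain amide, would give a step in this assay that lies beyond the scatter.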